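Replacing 3-methylthiophen-2-yl with 3-bromofuran-2-yl

This account rests on a few compounds, and the source may have more. Where it says the series, first, only, none or still open, it means among the compounds named here.

Compound 1 `COc1ccc(OC)c(C(=O)/C=C/c2ccsc2)c1`: 5300 nM
Compound 2 `COc1ccc(OC)c(C(=O)/C=C/c2ccc(C)s2)c1`: 1800 nM
Compound 3 `COc1ccc(OC)c(C(=O)/C=C/c2sccc2C)c1`: 19400 nM

These three values come from a functional assay on HT-29 cells (Homo sapiens) for cytotoxicity, read by MTT assay; on this read-out lower numbers stand for stronger inhibition and higher numbers for weaker inhibition. Compound 3 has the highest number of the three, which makes it the weakest here, and its gaps to the other two lie beyond the scatter. The next compound, compound 4 `COc1ccc(OC)c(C(=O)/C=C/c2occc2Br)c1`, carries 3-bromofuran-2-yl in place of 3-methylthiophen-2-yl on a double-bonded chain carbon bound to a double-bonded chain carbon.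

Two measured steps change the group at this same place: a 3.7-fold higher number from compound 1 to compound 3 (0.56 log units; beyond the scatter), which is modest, and an 11-fold higher number from compound 2 to compound 3 (1.03 log units; beyond the scatter), which is large. They show that this place can move the number considerably. Among the measured compounds shown here, neither of the other groups gave a number as high as compound 3, but no measured compound carries the entering group, so the direction remains uncertain. A modest drop is the expected outcome in this assay, estimated as a 2.2-fold lower number from compound 3 to compound 4 (0.33 log units; beyond the scatter). Compound 4 is estimated at 9000 nM, with an expected range from 2500 nM to 30000 nM.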

Compound 4, half-maximal inhibitory concentration: 15200 nM
Estimate against measurement, compound 4: 1.7-fold (0.23 log units) below, within the range that was stated.
By their numbers in this assay, from the lowest: compound 2; then compound 1; then compounds 4 and 3 (each within the scatter of the next).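

In this assay, the step to the new group reads a 1.3-fold lower number from compound 3 to compound 4 (0.11 log units; within the scatter), so 3-bromofuran-2-yl and 3-methylthiophen-2-yl cannot be told apart at this place, even though the ring's hetero atom and its substituent both differ. The other two steps, an 8.4-fold higher number from compound 2 to compound 4 (0.93 log units; beyond the scatter) and a 2.9-fold higher number from compound 1 to compound 4 (0.46 log units; beyond the scatter), lie beyond the scatter, so compounds 3 and 4, whose group names both carry a substituent at 3, share the high end, while the 5-methylthiophen-2-yl of compound 2 keeps the lowest number. Nothing available explains this grouping.

Compound 4 changes sulfur to oxygen and methyl to bromine at once, so the compounds shown cannot say what each swap does alone; 3-bromothiophen-2-yl would separate them. As far as these compounds go, how an amine or a carboxylic acid on the ring would read also stays open.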